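The compounds below may be only part of what the source reports. "The series", "measured", "known", "first", "only" and "open" are said of these compounds alone.

Compound 1 `COc1ccc2sc(NC(=O)c3ccc(C(F)(F)F)cc3)nc2c1`: > 10 ug/mL
Compound 2 `O=C(Nc1nc2ccc([N+](=O)[O-])cc2s1)c1ccc(C(F)(F)F)cc1`: 1.65 ug/mL
Compound 3 `O=C(Nc1nc2ccc(C(F)(F)F)cc2s1)c1ccc([N+](=O)[O-])cc1`: > 10 ug/mL

In a functional assay on NUGC-3 cells (Homo sapiens) for antiproliferative activity, read by sulforhodamine B assay (on this read-out higher numbers stand for weaker inhibition of growth and lower numbers for stronger inhibition of growth), compound 1 gives > 10 ug/mL, which is a limit of the assay and not a number. Compound 3 likewise gives only > 10 ug/mL, again a limit. Going by the values given here, compound 2 is the one compound that gives a number, 1.65 ug/mL. Compound 1 therefore stands at the limit of > 10 ug/mL in this assay, at which 2 of the 3 values shown sit. Compound 4 `COc1ccc(C(=O)Nc2nc3cc(OC)ccc3s2)cc1` differs from compound 1 by methoxy in place of trifluoromethyl on an aromatic carbon. Among the compounds with values here, no pair of measured compounds isolates this change, so its size is unknown. Compound 1 is known only by a limit, and the step is expected to stay within the scatter, a step that the limit leaves unreadable from compound 1 to compound 4. Compound 4 is expected to give 12 ug/mL, in the range 4 ug/mL to 40 ug/mL, with a good chance that only a limit is reported.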

Compound 4, concentration for 50% growth inhibition: > 10 ug/mL
Compound 4 ended at the assay's limit; the forecaster's own chance of this, stated with the estimate: 70%; the middle value is on the limit's open side.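

Compound 4, like compound 1, is known only by a limit and not by a number, so no step can be read between them: the limit of > 10 ug/mL in this assay, at which 3 of the 4 values shown sit.

The compounds shown leave open whether methoxy in place of trifluoromethyl on an aromatic carbon changes growth inhibition at all.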